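Extending Methyl to Ethyl on Compound 3

The compounds below may be only part of what the source reports. "The series", "measured", "known", "first", "only" and "open" are said of these compounds alone.

Tested in a functional assay on JAR cells (Homo sapiens) for inhibition, read by MTT assay, with a stated time of 72 h, tested at 10 uM (a higher number here means more inhibition at the concentration tested (going by the name of the read-out), a lower number less inhibition), are three compounds built on one shared core. Compound 1 `CCOC(=O)C1=C(Nc2ccccc2Br)S/C(=C\c2ccc[nH]2)C1=O` gives 62.7%. Compound 2 `CCOC(=O)C1=C(Nc2ccc(F)cc2)S/C(=C\c2ccc[nH]2)C1=O` gives 61.5%, and the step of a number 1.2 percentage points lower from compound 1 to compound 2 (within the scatter) stays within the scatter. Compound 3 `CCOC(=O)C1=C(Nc2ccc(C)cc2)S/C(=C\c2ccc[nH]2)C1=O` stands apart: its result, < 10%, is a limit of the assay rather than a number, so only a bound is known for it. This is the limit of < 10% in this assay, at which 1 of the 3 values shown sits. The steps of a number at least 52.7 percentage points lower from compound 1 to compound 3 (beyond the scatter) and a number at least 51.5 percentage points lower from compound 2 to compound 3 (beyond the scatter) are both large, so the number for compound 3 is lower than for either of the other two.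

Compound 4 `CCOC(=O)C1=C(Nc2ccc(CC)cc2)S/C(=C\c2ccc[nH]2)C1=O` has not yet been measured. It differs from compound 3 by methyl in place of hydrogen on a saturated chain carbon bound to an aromatic carbon. Within the data shown here, no measured step covers this kind of change; the two large steps concern the arrival of 4-methylphenyl, not its lengthening. Since compound 3 already sits at a limit, any further fall could not be seen, so the expected step that the limit leaves unreadable from compound 3 to compound 4 is none beyond the scatter. Compound 4 is estimated at 8%, within a range from 0% to 25%, and is expected most likely to be reported again only as a limit.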

Compound 4, a percentage reported as inhibition, at one concentration (the size of the read-out at that concentration, not a potency): < 10%
Compound 4 was reported as a limit; the forecaster's own chance of this, stated with the estimate: 70%; the middle value does not contradict the limit.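

Replacing 4-methylphenyl with 4-ethylphenyl does not close the gap to the two compounds that gave clear inhibition: the result is a number at least 51.5 percentage points lower from compound 2 to compound 4 (beyond the scatter), and likewise a number at least 52.7 percentage points lower from compound 1 to compound 4 (beyond the scatter). Among the compounds shown, the low reading at this position is therefore not confined to the methyl group, as one added carbon on that chain leaves it at a limit. Compound 3 and compound 4 both carry a limit rather than a number in this assay, so the step between them cannot be read, and neither can be placed above the other: the limit of < 10% in this assay, at which 2 of the 4 values shown sit.

As far as these compounds go, whether a longer chain such as propyl, or a chlorine atom in place of the ethyl, would stay at the limit or return towards the value of compound 2 remains open. Equally open, from the compounds shown here alone, is whether an amine or a hydroxyl group at the end of the ethyl chain would change the reading.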